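The compounds below may be only part of what the source reports. "The series", "measured", "known", "first", "only" and "open" are said of these compounds alone.

Measured in a physicochemical assay for acid dissociation:
- compound 1 `Clc1cc2nc(-c3ccncc3)[nH]c2cc1Cl` gives 9.33
- compound 2 `Clc1ccc2[nH]c(-c3ccncc3)nc2c1` gives 10

Compound 2 stands highest of the two measured compounds, with compound 1 the nearest. Compound 3 `c1ccc2[nH]c(-c3ccncc3)nc2c1` is not yet measured. It differs from compound 2 as follows: hydrogen in place of chloro on an aromatic carbon. Within the data shown here, the one measured step that bears on this is the same replacement, a number 0.67 log units higher from compound 1 to compound 2 (beyond the scatter). A step of similar size towards a higher number is therefore expected in this assay, namely a number 0.60 log units higher from compound 2 to compound 3 (beyond the scatter). The estimated value for compound 3 is 10.6, with an expected range from 10.2 to 11.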

Compound 3, acid dissociation constant: 11
Estimate against measurement, compound 3: 0.40 log units below; the range from low to high includes it.
By their numbers in this assay, from the lowest: compound 1; then compound 2; then compound 3.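

The second replacement of chloro by hydrogen on the shared core moves the number in the same direction as the first in this assay (a number 1.00 log units higher from compound 2 to compound 3 (beyond the scatter)), following the earlier step (a number 0.67 log units higher from compound 1 to compound 2 (beyond the scatter)). With compound 3, the six-membered aromatic ring of carbon only carries no chloro, and none of the three compounds goes against this direction. Nothing measured here accounts for the change. As far as these compounds go, whether another group on this aromatic carbon, such as methoxy, an amine or a nitrile, would follow the same direction remains open.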